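Working notes: compound 2 to its methyl analogue

A few compounds are considered here, and "the series" means these few. Any claim that something is new, unique, unknown or untested is made for them only; others in the source may bear on it.

- Compound 1 (`CCc1ccc(C(=O)/C=C/c2ccc3c(c2)B(O)OC3)cc1`) gives > 10 ug/mL as a limit of the assay.
- Compound 2 (`O=C(/C=C/c1ccc2c(c1)B(O)OC2)c1ccc(I)cc1`) gives > 10 ug/mL as a limit of the assay.

In an ADME assay on L929 cells (Mus musculus) for cytotoxicity, read by resazurin assay, with a stated time of 72 h (on this read-out lower numbers stand for stronger inhibition and higher numbers for weaker inhibition), compound 2 gives > 10 ug/mL as a limit and not as a number. Compound 2 therefore has no numeric place in the series, with the limit of > 10 ug/mL in this assay, at which 2 of the 2 values shown sit, as the whole record so far.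

The next compound is compound 3 (`Cc1ccc(C(=O)/C=C/c2ccc3c(c2)B(O)OC3)cc1`), which has methyl in place of iodo on an aromatic carbon, para to a large group.

Within the data shown here, one measured step bears on this change, and it is a step that the two limits leave unreadable from compound 1 to compound 2 with iodo in place of ethyl on an aromatic carbon. Its size offers no guide to the new step. With no readable size to carry over, the expected change is a step that the limit leaves unreadable from compound 2 to compound 3 in this assay and no direction beyond the scatter is anticipated.

Compound 3 is expected to read 15 ug/mL with an estimated range of 7 ug/mL to 30 ug/mL in this assay and may well return only a limit.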

Compound 3, half-maximal inhibitory concentration: > 10 ug/mL
Compound 3: no number, only a limit; the forecaster's own chance of this, stated with the estimate: 75%; the middle value is on the limit's open side.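

In this assay compound 3 gives > 10 ug/mL, a limit of the assay and not a number. Among these compounds, no step among compound 1, compound 2 and compound 3 can be read. The compounds shown leave open whether ethyl, iodo and methyl differ at all in this assay, and what numeric value any of the three compounds would have.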